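Hydroxycyclopentyl in place of isobutylsulfanyl on the acid carbon

The source may hold more compounds than are shown below. What is called first, only, known or untested is meant among the compounds shown, and "the series" means these compounds.

Compound 2 `CC(C)CSC(CCC/C=C(\c1ccccc1)c1cccnc1)C(=O)O` gives 110 nM in an assay (Equus caballus) for inhibition of Thromboxane-A synthase (Homo sapiens), using microsomes (a lower number here means a stronger inhibitor, a higher number a weaker inhibitor), the highest of the two numbers seen; its nearest neighbour is compound 1 `O=C(O)C(CCC/C=C(\c1ccccc1)c1cccnc1)C1=CCCC1`, which gives 60 nM. Within the data shown here, the one measured step, a 1.8-fold higher number from compound 1 to compound 2 (0.26 log units; within the scatter), lies within the scatter. Compound 3 `O=C(O)C(CCC/C=C(\c1ccccc1)c1cccnc1)C1(O)CCCC1` arises by the change (1-hydroxycyclopentyl in place of isobutylsulfanyl on a saturated chain carbon bound to a carbonyl carbon and a saturated chain carbon). Among the measured compounds shown here, the only step that bears on this is that from cyclopent-1-en-1-yl to isobutylsulfanyl, which was small, so no step beyond the scatter is expected; the estimate for compound 3 is 70 nM (range 30 nM to 180 nM), an expected step of a 1.6-fold lower number from compound 2 to compound 3 (0.20 log units; within the scatter).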

Compound 3, half-maximal inhibitory concentration: 65 nM
Beside the measured number, compound 3's estimate is 1.1-fold (0.03 log units) above it; the measured number falls inside the stated range.
By their numbers in this assay, from the lowest: compounds 1, 3 and 2 (each within the scatter of the next).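

In this assay, 1-hydroxycyclopentyl on this saturated chain carbon bound to a carbonyl carbon and a saturated chain carbon gives a 1.7-fold lower number from compound 2 to compound 3 (0.23 log units; within the scatter) and a 1.1-fold higher number from compound 1 to compound 3 (0.03 log units; within the scatter), so neither step leaves the scatter. The three groups seen at this position, one of them carrying a hydrogen-bond donor and two of them a five-membered ring, therefore cannot be told apart by this read-out. Nothing available explains this result. Going by these compounds, it remains open whether a primary amine or a longer alkyl chain at this position would give a step beyond the scatter.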